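The compounds below may be only part of what the source reports. "The series", "measured", "known", "first", "only" and "open" are said of these compounds alone.

Working notes on the series. In a functional assay on CHO cells for agonist activity at Free fatty acid receptor 1 (Mus musculus), read by FLIPR and calcium flux (a higher number here means that more compound is needed for the effect, a lower number that less compound is needed), compound 1 `CC#CC(c1ccc(OCc2ccccc2)cc1)C1OC(=O)NC1=O` gives 3710 nM, compound 2 `CC#CC(CC(=O)O)c1ccc(Oc2ncc(Br)cn2)cc1` gives 1480 nM, and compound 3 `CC#CC(CC(=O)O)c1ccc(Oc2ccc(C#N)cc2Br)cc1` gives 88 nM, the lowest of the three numbers; compound 2 is nearest and compound 1 furthest, both gaps lying beyond the scatter. Compound 4 `CC#CC(CC(=O)O)c1ccc(Oc2ccc(C#N)cc2Cl)cc1` differs from compound 3 by chloro in place of bromo on an aromatic carbon, ortho to a large group and meta to a cyano group. Going by the values given here, no measured pair in the set covers this exchange, so its size cannot be read from the numbers in hand. Such a swap is expected to shift the value only slightly, if at all beyond the scatter, perhaps a little upward. Compound 4 is therefore estimated at 120 nM in this assay, within 50 nM to 300 nM. The expected step is a 1.4-fold higher number from compound 3 to compound 4 (0.13 log units; within the scatter).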

Compound 4, half-maximal effective concentration: 48 nM
Compound 4: the middle estimate sits 2.5-fold (0.40 log units) above what was measured; the measured number lies below the stated range.
By their numbers in this assay, from the lowest: compounds 4 and 3 (each within the scatter of the next); then compound 2; then compound 1.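

The exchange of bromo for chloro on this aromatic carbon, ortho to a large group and meta to a cyano group, now has a measured size: a 1.8-fold lower number from compound 3 to compound 4 (0.26 log units; within the scatter) in this assay. At this position the assay therefore does not separate the two halogens. No measured information on the compounds offers a reason for this result.

Open, going by these compounds, is what a fluoro, methyl or methoxy group on this carbon would give. Also open, on these data alone, is whether the same exchange reads alike with an amide in place of the cyano group.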